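Swapping One Aromatic Group in a Growth Inhibitor Series

The compounds below may be only part of what the source reports. "The series", "measured", "known", "first", "only" and "open" are said of these compounds alone.

Of the compounds shown here, three have been measured so far in a functional assay on Gurav cells (Homo sapiens) for inhibition, read by sulforhodamine B assay; a higher number here means a weaker inhibitor of growth, a lower number a stronger inhibitor of growth. Compound 1 `Clc1cccc(-c2ccc(-c3ccc(-c4nc5ccccc5[nH]4)cc3)cc2)c1` gives 2190 nM, compound 2 `Oc1cccc2[nH]c(-c3ccc(-c4ccc(-c5ccc(F)cc5)cc4)cc3)nc12` gives 2860 nM, and compound 3 `COc1ccc(-c2ccc(-c3ccc(-c4nc5c(O)cccc5[nH]4)cc3)cc2)cc1` gives 6630 nM. Compound 3 therefore has the highest number of the three and is the weakest inhibitor of growth among them, beyond the scatter from both others.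

Compound 4 `Oc1cccc2[nH]c(-c3ccc(-c4ccc(-c5cccc(Cl)c5)cc4)cc3)nc12` keeps the hydroxyl-bearing core of compound 3, and only the outer group changes: 3-chlorophenyl in place of 4-methoxyphenyl on an aromatic carbon.

Going by the values given here, only one measured step bears directly on this place in the molecule: a 2.3-fold higher number from compound 2 to compound 3 (0.37 log units; beyond the scatter), a modest step that came with methoxy in place of fluoro. Compound 4 gives up that methoxy, so a step of similar size in the opposite direction seems reasonable. Compound 1 offers a second clue, since it carries the same 3-chlorophenyl group on a core without the hydroxyl and gives 2190 nM. Among the compounds with values here, no measured compound combines the hydroxyl with this group, so the expectation remains uncertain.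

The expected change is a 2.5-fold lower number from compound 3 to compound 4 (0.39 log units; beyond the scatter), a modest move to a lower number in this assay. For compound 4 the estimated value is 2700 nM, with an expected range of 1200 nM to 6000 nM.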

Compound 4, concentration for 50% growth inhibition: 2310 nM
Estimate against measurement, compound 4: 1.2-fold (0.07 log units) above, and the stated range covers the measured number.
By their numbers in this assay, from the lowest: compounds 1, 4 and 2 (each within the scatter of the next); then compound 3.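

In this assay the outer group does matter on the hydroxyl-bearing core, but only 4-methoxyphenyl stands apart so far: moving away from it gives a 2.9-fold lower number from compound 3 to compound 4 (0.46 log units; beyond the scatter), while the choice between the two halogen-bearing rings gives a 1.2-fold lower number from compound 2 to compound 4 (0.09 log units; within the scatter). The first direct view of the hydroxy on the core comes from a 1.1-fold higher number from compound 1 to compound 4 (0.02 log units; within the scatter), so with 3-chlorophenyl as the outer group, adding this hydroxy leaves the growth-inhibition number unchanged within the usual scatter. No measurement here gives a reason for the separation of 4-methoxyphenyl from the other two outer groups.

On these data alone, that reading of the hydroxy rests on a single pair of compounds, so it remains open whether the hydroxy would also make no difference with 4-methoxyphenyl or 4-fluorophenyl as the outer group. As far as these compounds go, it is also open how an outer ring carrying an amine or a carboxylic acid would compare, and whether 4-chlorophenyl would match 3-chlorophenyl or fall closer to 4-methoxyphenyl.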